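Swapping One Amide Amine on a Furan-Thiophene Pair

The compounds below may be only part of what the source reports. "The series", "measured", "known", "first", "only" and "open" are said of these compounds alone.

Measured so far:
compound 1, `CC1=C(C(=O)NC(C)C)C(c2ccoc2)NC(=O)N1`, gives 3% in an assay on membranes from HeLa cells for displacement of a labelled ligand from adenosine receptor A3 (Homo sapiens), read by scintillation counting, with a stated time of 180 min, tested at 1 uM; on this read-out higher numbers stand for more inhibition at the one concentration tested (going by the name of the read-out) and lower numbers for less inhibition
compound 2, `CCN(CC)C(=O)C1=C(C)NC(=O)NC1c1ccoc1`, gives 37% in this assay
compound 3, `CC1=C(C(=O)NC(C)C)C(c2cccs2)NC(=O)N1`, gives 1% in this assay

All three share a core; compound 3 differs from compound 1 only by thiophen-2-yl in place of furan-3-yl on a saturated ring carbon, and this gave a number 2 percentage points lower from compound 1 to compound 3 (within the scatter). Compound 2 differs from compound 1 by diethylamino in place of isopropylamino on a carbonyl carbon, which gave a number 34 percentage points higher from compound 1 to compound 2 (beyond the scatter). Compound 4, `CCN(CC)C(=O)C1=C(C)NC(=O)NC1c1cccs1`, is not yet measured; it differs from compound 3 by diethylamino in place of isopropylamino on a carbonyl carbon, the same change made at the same place. Among the compounds with values here, the step expected from compound 3 to compound 4 is a number 32 percentage points higher from compound 3 to compound 4 (beyond the scatter), resting on a number 34 percentage points higher from compound 1 to compound 2 (beyond the scatter) seen in the one earlier pair. Compound 4 is therefore estimated at 33%, most likely between 10% and 55%.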

Compound 4, a percentage reported as inhibition, at one concentration (the size of the read-out at that concentration, not a potency): 31%
For compound 4 the middle estimate is 2 percentage points above the measured one; measured number inside the range.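

In this assay, diethylamino in place of isopropylamino on a carbonyl carbon also raises the number when thiophen-2-yl is present, giving a number 30 percentage points higher from compound 3 to compound 4 (beyond the scatter), and the change carries over at much the same size: the same change on two cores in this assay, a number 34 percentage points higher (beyond the scatter) from compound 1 to compound 2 and a number 30 percentage points higher (beyond the scatter) from compound 3 to compound 4, 4 percentage points apart, within the scatter of two such steps

Thiophen-2-yl in place of furan-3-yl stays a small step with diethylamino as well, giving a number 6 percentage points lower from compound 2 to compound 4 (within the scatter), which matches the earlier swap: the same change on two cores in this assay, a number 2 percentage points lower (within the scatter) from compound 1 to compound 3 and a number 6 percentage points lower (within the scatter) from compound 2 to compound 4, 4 percentage points apart, within the scatter of two such steps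

This rests on just two pairs of compounds at one concentration, so it shows that the change carried between these two cores, but not that it would carry to other cores, nor why it raises the number.

Still open, as far as these compounds go, is how a ring amine such as piperidine or a longer chain such as dipropylamino would behave on the carbonyl carbon. Also open, from the compounds shown here alone, is whether the same step would appear with phenyl on the saturated ring carbon.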